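The source may report more compounds than this note shows. Statements on the series, on what has been measured and on what is new or still open speak of the compounds shown alone.

Working notes on the series. In a functional assay on MDA-MB-231 cells (Homo sapiens) for inhibition, read by sulforhodamine B assay, with a stated time of 48 h (on this read-out lower numbers stand for higher toxicity in this test and higher numbers for lower toxicity in this test), compound 3 `COc1cc(-c2nn(-c3cccc(NC(=O)Nc4ccc(Cl)c(Cl)c4)c3)cc2-c2ccncc2)ccc1Cl` gives 12900 nM. Among the measured compounds shown here, it carries the only plain number in the set; the two other results are limits. For compound 2 `COc1cc(-c2nn(-c3cccc(NC(=O)c4cccc(C(F)(F)F)c4)c3)cc2-c2ccncc2)ccc1Cl` the result is a limit, > 50000 nM. For compound 1 `O=C(Nc1cccc(-n2cc(-c3ccncc3)c(-c3ccc(Cl)c(O)c3)n2)c1)Nc1cccc(C(F)(F)F)c1` the result is likewise a limit, > 32500 nM. For the measured compounds named here, the single measured step, an at least 3.8-fold lower number from compound 2 to compound 3 (0.58 log units; beyond the scatter), rests on the limit of > 50000 nM in this assay, at which 1 of the 3 values shown sits, and therefore bounds the change only from one side.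

Compound 4 `O=C(Nc1cccc(-n2cc(-c3ccncc3)c(-c3ccc(Cl)c(O)c3)n2)c1)Nc1ccc(Cl)c(Cl)c1` differs from compound 3 by hydrogen in place of methyl on an oxygen on an aromatic ring. Going by the values given here, no measured step bears on this change. Compound 1 carries the same hydroxy group as compound 4 and differs from it at the urea end, but its result is only (the limit of > 32500 nM in this assay, at which 1 of the 3 values shown sits), so it gives no number to lean on. With nothing showing a shift for this change, the expected step is a 1.2-fold higher number from compound 3 to compound 4 (0.07 log units; within the scatter), within the scatter. Compound 4 is accordingly estimated at 15000 nM, with a range from 6000 nM to 40000 nM, and a fair chance that only a limit is returned.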

Compound 4, concentration lethal to 50% of the cells: > 32500 nM
Compound 4 was reported as a limit; the forecaster's own chance of this, stated with the estimate: 25%; at least 2.1-fold (0.33 log units) between middle value and limit.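

In this assay, among the compounds shown here, the change from methoxy to hydroxy gives an at least 2.5-fold higher number from compound 3 to compound 4 (0.40 log units; beyond the scatter), the first reading at this position, and it is bounded from one side only. The result for compound 4 is a limit, and compound 1 sits at the same limit: the limit of > 32500 nM in this assay, at which 2 of the 4 values shown sit. Among the compounds shown, only the methoxy compound 3 gives a plain number, 12900 nM, while the step between the two hydroxy compounds, compound 1 and compound 4, cannot be read.

Going by these compounds, how far the number for compound 4 lies past its limit remains open, so the true size of the step is unknown. Also open, on these data alone, is whether an ethoxy group or an amine in place of the methoxy would keep the number of compound 3 or move it in the direction hydroxy does.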